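The compounds below may be only part of what the source reports. "The series", "measured", "known", "first", "only" and "open" are said of these compounds alone.

Measured compounds:
compound 1, `CC/C(=C(/c1ccc(/C=C/C(=O)O)cc1)c1cc2ccccc2[nH]1)c1ccccc1`: 108 nM
compound 2, `CC/C(=C(/c1ccc(/C=C/C(=O)O)cc1)c1cc2ccccc2[nH]1)c1ccccc1C`: 33 nM
compound 3, `CC/C(=C(/c1ccc(/C=C/C(=O)O)cc1)c1cc2ccccc2[nH]1)c1ccc(OC)cc1`: 61 nM

All three share one core and differ only in the ring attached to the double-bonded chain carbon bound to a double-bonded chain carbon and a saturated chain carbon. In a functional assay on MCF7 cells (Homo sapiens) for inhibition (on this read-out higher numbers stand for weaker inhibition and lower numbers for stronger inhibition), compound 1 stands with the highest of the three numbers, though its gap to compound 3 lies within the scatter. Two steps leave compound 1: a 3.3-fold lower number from compound 1 to compound 2 (0.51 log units; beyond the scatter), which is beyond the scatter, and a 1.8-fold lower number from compound 1 to compound 3 (0.25 log units; within the scatter), which is not. Between the two substituted analogues, a 1.8-fold higher number from compound 2 to compound 3 (0.27 log units; within the scatter), again within the scatter.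

Compound 4, `CC/C(=C(/c1ccc(/C=C/C(=O)O)cc1)c1cc2ccccc2[nH]1)c1cccc(Cl)c1Cl`, has not yet been measured in this assay. It differs from compound 1 in one place: 2,3-dichlorophenyl in place of phenyl on a double-bonded chain carbon bound to a double-bonded chain carbon and a saturated chain carbon. Among the compounds with values here, the two measured steps from compound 1 that bear on this change both go to lower numbers, one modestly, one within the scatter, and no step with a chlorine-bearing ring is known. A small to modest lowering is therefore the most that can reasonably be expected, with a fair chance of no change beyond the scatter. Compound 4 is expected to give about 50 nM, within a range from 20 nM to 130 nM. That estimate corresponds to an expected step of a 2.2-fold lower number from compound 1 to compound 4 (0.33 log units; beyond the scatter).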

Compound 4, half-maximal inhibitory concentration: 898 nM
Beside the measured number, compound 4's estimate is 18-fold (1.25 log units) below it, outside the stated range (above it).
By their numbers in this assay, from the lowest: compounds 2, 3 and 1 (each within the scatter of the next, the first and the last beyond it); then compound 4.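

The position on the double-bonded chain carbon can move the number upward as well as downward in this assay (an 8.3-fold higher number from compound 1 to compound 4 (0.92 log units; beyond the scatter)), whereas 2-methylphenyl and 4-methoxyphenyl had given only lower numbers than phenyl. Substitution of this ring therefore does not lower the number in general, and 2,3-dichlorophenyl is the exception among the rings shown, with still larger steps from the two substituted analogues (a 15-fold higher number from compound 3 to compound 4 (1.17 log units; beyond the scatter); a 27-fold higher number from compound 2 to compound 4 (1.43 log units; beyond the scatter)). Nothing available explains why this ring weakens inhibition.

The compounds shown leave open whether the rise requires both chlorines, which 2-chlorophenyl and 3-chlorophenyl would address. They also leave open whether it is specific to chlorine, which 2,3-dimethylphenyl would test.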